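The source may report more compounds than this note shows. Statements on the series, on what has been measured and on what is new or still open speak of the compounds shown alone.

Working notes on the series.

Compound 1 `C[C@H](Nc1nc(N)nc(N)c1C#N)c1cc2ccc(F)cn2c(=O)c1-c1ccccc1` and compound 2 `C[C@H](Nc1nc(N)nc(N)c1C#N)c1cc2ccc(F)cn2c(=O)c1-c1ccc(F)cc1` share one core and differ only in the change (fluoro in place of hydrogen on an aromatic carbon). In an ADME assay on microsomes from liver (Rattus norvegicus), read by LC-MS, using NADPH, with a stated time of 30 min, tested at 1 uM (a higher number here means that more of the compound is left, a lower number that less of the compound is left), compound 1 gives 88% and compound 2 gives 87%, so the step of a number 1 percentage points lower from compound 1 to compound 2 (within the scatter) sits within the scatter of the method. Compound 3 `C[C@H](Nc1ncnc(N)c1C#N)c1cc(=O)n2cc(F)ccc2c1-c1ccccc1` carries a different core; the difference between the two cores is not broken down here. In this assay compound 3 gives 74%, a number that lies beyond the scatter under both compound 1 and compound 2, so compound 3 stands lowest of the three measured compounds.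

Compound 4 `C[C@H](Nc1ncnc(N)c1C#N)c1cc(=O)n2cc(F)ccc2c1-c1cccc(F)c1` is not yet measured. It arises from compound 3 by the change (fluoro in place of hydrogen on an aromatic carbon). Within the data shown here, this is the same kind of change as the one from compound 1 to compound 2, but not the same: in the measured pair the fluoro enters para to a large group, while in compound 4 it enters meta to a large group. Among the measured compounds shown here, the measured pair offers the only guide to the size of the step.

For compound 4 in this assay the step of a number 1 percentage points lower from compound 3 to compound 4 (within the scatter) is expected, resting on the near-flat step a number 1 percentage points lower from compound 1 to compound 2 (within the scatter) seen for the same kind of change, with the different core of compound 3 as the main source of doubt. The estimate for compound 4 is therefore 73%, with a range from 60% to 84%.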

Compound 4, percent of the compound remaining: 79%
Estimate against measurement, compound 4: 6 percentage points below; the measured number falls inside the stated range.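

In this assay the change from phenyl to 3-fluorophenyl gives a number 5 percentage points higher from compound 3 to compound 4 (within the scatter), so on this second core, as on the first, the added fluoro leaves the percent of compound remaining within the usual scatter. Set beside the earlier step, the new one does not differ from it, and the change carries over from one core to the other without a detectable difference: the same change on two cores in this assay, a number 1 percentage points lower (within the scatter) from compound 1 to compound 2 and a number 5 percentage points higher (within the scatter) from compound 3 to compound 4, 6 percentage points apart, within the scatter of two such steps

Among these compounds, this does not show that the change is without effect on every core of the series, since it rests on only two pairs of compounds, and it does not separate the influence of the core from that of the place on the ring, since the fluoro in compound 4 stands meta to a large group and does not occupy the same place as in compound 2.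

Still open, as far as these compounds go, is whether the fluoro at one and the same place on the ring would behave alike on both cores. Also open, from the compounds shown here alone, is whether a different group on that ring, such as chloro, methoxy, an amine or a carboxylic acid, would move the number in this assay beyond the scatter on either core.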